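The compounds below may be only part of what the source reports. "The series", "measured", "known", "first", "only" and "open" are said of these compounds alone.

Of the compounds shown here, three on one shared core have been measured so far. In a functional assay on HCT-116 cells (Homo sapiens) for inhibition, read by MTT assay, with a stated time of 2 days, tested at 100 uM (on this read-out lower numbers stand for less inhibition of growth and higher numbers for more inhibition of growth at the one concentration tested), compound 1 `CNC(=O)c1cc(Oc2ccc3nc(NC(=O)c4ccc(Cl)cc4Cl)sc3c2)ccn1` gives 64.4%, compound 2 `CNC(=O)c1cc(Oc2ccc3nc(NC(=O)c4ccc(Cl)cc4)sc3c2)ccn1` gives 80.5%, and compound 3 `CNC(=O)c1cc(Oc2ccc3nc(NC(=O)Nc4ccc(N5CCN(C)CC5)cc4)sc3c2)ccn1` gives 95%. Between the first two there is a single change, hydrogen in place of chloro on an aromatic carbon, and a number 16.1 percentage points higher from compound 1 to compound 2 (beyond the scatter). Compound 3 stands highest of the three numbers, beyond the scatter above both compound 2 and compound 1. Compound 4 `CNC(=O)c1cc(Oc2ccc3nc(NC(=O)Nc4ccc(Cl)cc4)sc3c2)ccn1` differs from compound 3 by chloro in place of 4-methylpiperazin-1-yl on an aromatic carbon. Going by the values given here, no measured step covers this exchange directly: the step from compound 1 to compound 2 concerns only the presence of a chloro, and the two measured chloro-bearing compounds sit below compound 3. A moderate downward step is therefore expected, a number 15 percentage points lower from compound 3 to compound 4 (beyond the scatter). For compound 4 the estimate in this assay is 80%, within 60% to 95%.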

Compound 4, percent growth inhibition at one concentration: 85.2%
For compound 4 the middle estimate is 5.2 percentage points below the measured one, and the stated range covers the measured number.
By their numbers in this assay, from the lowest: compound 1; then compounds 2, 4 and 3 (each within the scatter of the next, the first and the last beyond it).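

In this assay, chloro in place of 4-methylpiperazin-1-yl gives a number 9.8 percentage points lower from compound 3 to compound 4 (within the scatter), so on this aromatic carbon the loss of the whole ring leaves no change beyond the scatter. On the carbonyl carbon, (4-chlorophenyl)amino in place of 4-chlorophenyl gives a number 4.7 percentage points higher from compound 2 to compound 4 (within the scatter), whereas (4-chlorophenyl)amino in place of 2,4-dichlorophenyl gives a number 20.8 percentage points higher from compound 1 to compound 4 (beyond the scatter). No available evidence bears on these results. Going by these compounds, whether a morpholine ring, a primary amine or a carboxylic acid at the chloro position would hold the number remains open. So does how the urea-linked compounds would compare at lower concentrations.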